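From Phenyl to Ethyl: Expected Lipophilicity of Compound 4

The source may hold more compounds than are shown below. What is called first, only, known or untested is meant among the compounds shown, and "the series" means these compounds.

Compound 1, `CC(C)C/C(=N\C#N)N(C)Cc1ccc(Cl)nc1`: 1.75
Compound 2, `CCC/C(=N\C#N)N(C)Cc1ccc(Cl)nc1`: 1.55
Compound 3, `CN(Cc1ccc(Cl)nc1)/C(=N/C#N)c1ccccc1`: 1.86

These three compounds were measured in a physicochemical assay for lipophilicity, read by HPLC, using the shake flask method; a higher number here means a more lipophilic compound, a lower number a more polar compound. Compound 3 gives the highest number of the three; compound 1 lies nearest, separated by a number 0.11 log units higher from compound 1 to compound 3 (within the scatter), and compound 2 lies furthest, as a number 0.31 log units higher from compound 2 to compound 3 (beyond the scatter) shows. Compound 4, `CC/C(=N\C#N)N(C)Cc1ccc(Cl)nc1`, has not been measured; it differs from compound 3 by ethyl in place of phenyl on a carbon with a double bond to nitrogen. Among the measured compounds shown here, two steps bear on this change. The move from propyl to phenyl, a number 0.31 log units higher from compound 2 to compound 3 (beyond the scatter), runs opposite to the direction now taken, and the trimming of the chain, a number 0.20 log units lower from compound 1 to compound 2 (within the scatter), points the same way. Compound 4 is therefore expected to give a lower number, a step of a number 0.56 log units lower from compound 3 to compound 4 (beyond the scatter). The value of compound 4 in this assay is estimated at 1.3, between 1 and 1.6.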

Compound 4, partition coefficient: 1.12
Compound 4: the middle estimate sits 0.18 log units above what was measured; the range from low to high includes it.
By their numbers in this assay, from the lowest: compound 4; then compounds 2, 1 and 3 (each within the scatter of the next, the first and the last beyond it).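

In this assay, ethyl on this carbon with a double bond to nitrogen sets compound 4 apart from all three earlier compounds, with a number 0.74 log units lower from compound 3 to compound 4 (beyond the scatter) for ethyl in place of phenyl. Isobutyl and propyl lay within the scatter of each other, but the shorter ethyl chain is resolved from both, with a number 0.43 log units lower from compound 2 to compound 4 (beyond the scatter) on trimming one methyl and a number 0.63 log units lower from compound 1 to compound 4 (beyond the scatter) against the isobutyl chain. No measurement shown explains these steps. Still open, on these data alone, is how methyl, a longer chain, an amine or a ring other than phenyl would read at this carbon.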